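This account rests on a few compounds, and the source may have more. Where it says the series, first, only, none or still open, it means among the compounds named here.

Values measured in a functional assay on KB cells (Homo sapiens) for inhibition, read by MTT assay, with a stated time of 24 h, tested at 100 ug/mL (on this read-out lower numbers stand for less inhibition of growth and higher numbers for more inhibition of growth at the one concentration tested), stand as follows
Compound 1 (`CC(=O)SCCC(CCCCC(=O)O)SC(C)=O`) gives 8.03%
Compound 2 (`O=C(CCCCC1CCSS1)Nc1cccc(C(F)(F)F)c1`) gives 80%
Compound 3 (`O=C(CCCCC(S)CCS)Nc1cccc(Cl)c1`) gives 8.04%

Compound 3 stands level with compound 1 within the scatter, and far under compound 2, a gap beyond the scatter. The next compound for this assay is compound 4 (`Cc1cccc(NC(=O)CCCCC(S)CCS)c1`), which has methyl in place of chloro on an aromatic carbon. For the measured compounds named here, no two measured compounds differ in one place only, so no measured step shows the size of this swap. Starting from compound 3 at 8.04% in this assay, no step beyond the scatter is expected. The estimated step of a number 1 percentage points higher from compound 3 to compound 4 (within the scatter) stays within the scatter. For compound 4 the estimate is 9% with an expected range from 2% to 22% in this measurement.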

Compound 4, percent growth inhibition at one concentration: 17.5%
Estimate against measurement, compound 4: 8.5 percentage points below; the range from low to high includes it.
By their numbers in this assay, from the lowest: compounds 1, 3 and 4 (each within the scatter of the next); then compound 2.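

In this assay, for the compounds shown here, the measured step of a number 9.5 percentage points higher from compound 3 to compound 4 (within the scatter) is the first single-place comparison, and it shows that methyl in place of chloro on this aromatic carbon stays within the scatter. At this one position, then, the two groups cannot be told apart on this read-out. Nothing measured on hand bears on this result. From the compounds shown here alone, it remains open whether an amine or a carboxylic acid on the same aromatic carbon would also stay within the scatter. Also open, going by these compounds, is whether methyl or chloro would give a similar reading on the core of compound 2.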